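A few compounds are considered here, and "the series" means these few. Any claim that something is new, unique, unknown or untested is made for them only; others in the source may bear on it.

Compounds measured in an assay on Cerebral cortex (strain Sprague-Dawley) for displacement of a labelled ligand from Neuronal acetylcholine receptor; alpha4/beta2 (Rattus norvegicus); on this read-out higher numbers stand for weaker inhibition and lower numbers for stronger inhibition:
compound 1, `CN1CCC[C@H]1[C@@H]1COc2ccc(O)cc2O1`: 12 nM
compound 2, `CN1CCC[C@H]1[C@H]1COc2ccc(O)cc2O1`: 421 nM
compound 3, `Oc1ccc2c(c1)O[C@@H]([C@@H]1CCCN1)CO2`: 1200 nM

Compound 3 stands highest of the three numbers in this assay; its nearest neighbour is compound 2, reached through a 2.9-fold higher number from compound 2 to compound 3 (0.45 log units; beyond the scatter), and compound 1 is furthest from it. Compound 4, `Oc1ccc2c(c1)O[C@H]([C@@H]1CCCN1)CO2`, differs from compound 3 in one respect: the two compounds have the same atoms and bonds and differ only in configuration as drawn: 1 of 2 stereo elements differ; a stereocentre at a saturated ring carbon is drawn S in compound 3 and R in compound 4. The measured step that bears on this is a 35-fold higher number from compound 1 to compound 2 (1.55 log units; beyond the scatter); the fact that compounds 1 and 2 differ only in the configuration as drawn ties that large rise entirely to the inversion of the same ring stereocentre, drawn R in compound 1 and S in compound 2. The step from compound 3 to compound 4 runs the other way, from S back to R, so a large fall in the number is expected in this assay, roughly undoing that rise. The modest change seen in a 2.9-fold higher number from compound 2 to compound 3 (0.45 log units; beyond the scatter) suggests that the ring nitrogen methyl matters far less than the configuration. Compound 4 is therefore expected to sit at 35 nM in this assay, between 10 nM and 120 nM, a step of a 34-fold lower number from compound 3 to compound 4 (1.54 log units; beyond the scatter).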

Compound 4, inhibition constant: 9000 nM
The estimate for compound 4 lay 260-fold (2.41 log units) below the measured number, and the stated range ends below it.
By their numbers in this assay, from the lowest: compound 1; then compound 2; then compound 3; then compound 4.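

In this assay, inverting the saturated ring carbon from S to R gives a 7.5-fold higher number from compound 3 to compound 4 (0.88 log units; beyond the scatter), so without the methyl the drawn R form no longer has the lower number, as it did in the methyl pair, and this reversal can be assigned to the inversion alone: the fact that compounds 3 and 4 differ only in the configuration as drawn

Hydrogen in place of methyl on an amine nitrogen in a ring gives a 750-fold higher number from compound 1 to compound 4 (2.88 log units; beyond the scatter) with that carbon drawn R, so the size of this change depends on the configuration: the same change on two cores in this assay, a 2.9-fold higher number (0.45 log units; beyond the scatter) from compound 2 to compound 3 and a 750-fold higher number (2.88 log units; beyond the scatter) from compound 1 to compound 4, 260-fold (2.42 log units) apart, beyond the scatter of two such steps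

The compounds shown leave open whether an ethyl group on that nitrogen would follow the methyl pair or the hydrogen pair. They also leave open whether this dependence would survive with a methoxy group in place of the hydroxyl on the shared core.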